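Swapping a bromobenzyl thioether for a benzoylmethyl thioether

The source may hold more compounds than are shown below. What is called first, only, known or untested is meant among the compounds shown, and "the series" means these compounds.

Measured so far:
Compound 1, `Cc1cc(Nc2cc(-c3ccccc3)[nH]n2)n2nc(SCc3cccc(Br)c3)nc2n1`, gives 4820 nM in a functional assay on MGC-803 cells (Homo sapiens) for inhibition, read by MTT assay, with a stated time of 72 h; on this read-out higher numbers stand for weaker inhibition and lower numbers for stronger inhibition.
Compound 2, `Cc1nc2nc(SCc3ccc(Cl)cc3)nn2c(Nc2cc(-c3ccccc3)[nH]n2)c1C`, gives 9050 nM in this assay.

Going by the values given here, only two compounds carry numbers. Compound 1 holds the lower of the two, but the gap between compound 1 and compound 2 lies within the usual scatter of repeated measurements, so the two cannot be told apart on this evidence. Compound 3, `Cc1cc(Nc2cc(-c3ccccc3)[nH]n2)n2nc(SCC(=O)c3ccccc3)nc2n1`, has not yet been measured. It differs from compound 1 in one place: benzoyl in place of 3-bromophenyl on a saturated chain carbon bound to a sulfur. Among the compounds with values here, no measured pair shares this change, so nothing here shows its effect, and the safest expectation is a step that stays within the scatter. The estimated step is a 1.2-fold higher number from compound 1 to compound 3 (0.10 log units; within the scatter) in this assay. Compound 3 is therefore expected to give about 6000 nM, with a likely range from 2000 nM to 20000 nM.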

Compound 3, half-maximal inhibitory concentration: 2580 nM
Compound 3: the middle estimate sits 2.3-fold (0.37 log units) above what was measured, within the range that was stated.
By their numbers in this assay, from the lowest: compounds 3, 1 and 2 (each within the scatter of the next, the first and the last beyond it).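

In this assay, the exchange of benzoyl for 3-bromophenyl on a saturated chain carbon bound to a sulfur gives a 1.9-fold lower number from compound 1 to compound 3 (0.27 log units; within the scatter), so compound 1 and compound 3 cannot be told apart. Going by these compounds alone, this is the first single-place comparison, and it shows that this position can lose the bromine and gain a carbonyl, which counts as a hydrogen-bond acceptor, without a difference that stands clear of the scatter. No measurement shown here explains this result.

A single pair cannot show whether the carbonyl, the bromine or the length of the chain matters on its own. Going by these compounds, a plain benzyl group, a longer chain such as 3-phenylpropyl, or an amine or carboxylic acid at this position could help separate these parts, and their effects remain open.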